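Swapping a Benzyl Ether for a Carbamate

The compounds below may be only part of what the source reports. "The series", "measured", "known", "first", "only" and "open" are said of these compounds alone.

In a functional assay on V79-379A cells (Cricetulus griseus) for cytotoxicity, read by MTT assay, in the presence of a further agent that is not named here (on this read-out lower numbers stand for stronger inhibition and higher numbers for weaker inhibition), compound 1 `COC1=CC(=O)c2c(c(CCl)cn2C)C1=O` gives 33000 nM, and compound 2 `COC1=CC(=O)c2c(c(COC(=O)c3ccc(F)cc3)cn2C)C1=O` gives 50 nM. Compound 3 `COC1=CC(=O)c2c(c(COCc3ccccc3)c(C)n2C)C1=O` reads 410000 nM, the highest and so the weakest of the three numbers, with both gaps beyond the scatter. Compound 4 `COC1=CC(=O)c2c(c(COC(N)=O)c(C)n2C)C1=O` differs from compound 3 in one place: carbamoyl in place of benzyl on an oxygen on a saturated carbon. For the measured compounds named here, no measured pair isolates this change, so any forecast is loose. Compound 2 also has a carbonyl group on such an oxygen and gives 50 nM, although it differs from compound 3 elsewhere too. A large move toward stronger inhibition, beyond the scatter, is therefore expected, and the expected change is an 82-fold lower number from compound 3 to compound 4 (1.91 log units; beyond the scatter). The estimated value for compound 4 is 5000 nM, within an expected range of 300 nM to 60000 nM.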

Compound 4, half-maximal inhibitory concentration: 300 nM
For compound 4 the middle estimate is 17-fold (1.22 log units) above the measured one; the measured number falls inside the stated range.
By their numbers in this assay, from the lowest: compound 2; then compound 4; then compound 1; then compound 3.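

On an oxygen on a saturated carbon, the group attached strongly affects the result in this assay: carbamoyl in place of benzyl gives a 1400-fold lower number from compound 3 to compound 4 (3.14 log units; beyond the scatter) and is a large step. For the compounds shown here, this is the first pair here that differs in only one place, so the shift can be tied to this single change. Nothing available explains why the step is so large. Still open, going by these compounds, is how an acetyl group, or a carbamoyl with a methyl on its nitrogen, would read on the same oxygen.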